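The compounds below may be only part of what the source reports. "The series", "measured", "known", "first", "only" and "open" are said of these compounds alone.

Working notes on the series, read in an ADME assay on the whole organism (Mus musculus, strain C57BL6/N) for pharmacokinetics, read by LC-MS, with a stated time of 24 h, at a dose of 50 mg/kg by the oral route; on this read-out lower numbers stand for lower exposure and higher numbers for higher exposure at the dose given. Among the measured compounds shown here, compound 1 `NC(=O)c1cnc2c(c1)CCN2` gives 176000 nM, and compound 2 `Cc1c(C(N)=O)cnc2c1CCN2` gives 76400 nM, the lower of the two numbers so far. For the measured compounds named here, the only measured step is a 2.3-fold lower number from compound 1 to compound 2 (0.36 log units; beyond the scatter), with methyl in place of hydrogen on an aromatic carbon.

Compound 3 `Cc1c(C(N)=O)cnc2c1C[C@@H](C)N2` differs from compound 2 in one place: methyl in place of hydrogen on a saturated ring carbon. This is methyl in place of hydrogen on a saturated ring carbon, next to the ring nitrogen.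

Going by the values given here, one measured step bears on this change, and only loosely. The step of a 2.3-fold lower number from compound 1 to compound 2 (0.36 log units; beyond the scatter) also brings in a methyl, but on an aromatic carbon rather than a saturated ring carbon, and one pair sets no trend. The working expectation in this assay is therefore a modest move of similar size towards lower numbers, with little or no change still plausible. The expected move is a 2.2-fold lower number from compound 2 to compound 3 (0.34 log units; beyond the scatter). The estimate for compound 3 is 35000 nM, with an expected range of 14000 nM to 90000 nM.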

Compound 3, maximal plasma concentration: 58600 nM
The estimate for compound 3 lay 1.7-fold (0.22 log units) below the measured number; the measured number falls inside the stated range.
By their numbers in this assay, from the lowest: compounds 3 and 2 (each within the scatter of the next); then compound 1.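

In this assay, a methyl on this saturated ring carbon, next to the ring nitrogen, gives a 1.3-fold lower number from compound 2 to compound 3 (0.12 log units; within the scatter), so compound 2 and compound 3 cannot be told apart on this read-out and the position takes the added methyl without a step beyond the scatter. The earlier methyl, on an aromatic carbon, gave a 2.3-fold lower number from compound 1 to compound 2 (0.36 log units; beyond the scatter), which is printed as beyond the scatter, so the two placements of a methyl do not read alike here, although each rests on a single pair and neither sets a trend. Nothing available accounts for either step or for the contrast between them.

Going by these compounds, compound 3 carries one configuration at this carbon, so whether the opposite configuration reads the same in this assay remains open. Also open, on these data alone, is whether this carbon would tolerate more than a methyl, such as an ethyl, a longer chain, an amine or a carboxylic acid, since a single methyl within the scatter says nothing about how far the position can be built on.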